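This account rests on a few compounds, and the source may have more. Where it says the series, first, only, none or still open, it means among the compounds named here.

The measured compounds:
Compound 1, `CC(=O)/C(=N\c1cccc(F)c1)NNc1ccccc1C`: in an assay on isolated protein for binding affinity to corticotropin-releasing factor receptor 1 (Homo sapiens) (on this read-out lower numbers stand for stronger inhibition and higher numbers for weaker inhibition), compound 1 gives 43 nM.
Compound 2, `CC(=O)/C(=N\c1ccc(Cl)cc1)NNc1ccccc1C(F)(F)F`: in this assay compound 2 gives only a limit of the assay, > 10000 nM.
Compound 3, `CC(=O)/C(=N\c1cccc(C)c1)NNc1ccccc1C(F)(F)F`: in this assay compound 3 gives 1420 nM.

Among the numbers shown, compound 3 stands at the highest of the two; the nearest is compound 1, whose number is lower by a gap beyond the scatter, and the remaining value is a limit. Compound 4, `CC(=O)/C(=N\c1cccc(F)c1)NNc1ccccc1C(F)(F)F`, is not yet measured. It differs from compound 3 by fluoro in place of methyl on an aromatic carbon. For the measured compounds named here, no measured step swaps methyl for fluoro. Going by the values given here, the one measured step on the same ring, an at least 7.0-fold lower number from compound 2 to compound 3 (0.84 log units; beyond the scatter), shows that a group on that ring can move the number at least modestly, though one end of that step sits at the limit (the limit of > 10000 nM in this assay, at which 1 of the 3 values shown sits). Compound 1 carries the 3-fluorophenyl ring that compound 4 receives, yet its other ring differs as well, so its number cannot be assigned to a single change. A modest lowering is expected, a 2.0-fold lower number from compound 3 to compound 4 (0.31 log units; beyond the scatter). Compound 4 is therefore estimated at 700 nM, between 150 nM and 3000 nM.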

Compound 4, inhibition constant: 197 nM
For compound 4 the middle estimate is 3.6-fold (0.55 log units) above the measured one; measured number inside the range.
By their numbers in this assay, from the lowest: compound 1; then compound 4; then compound 3. At a limit, above all of these: compound 2.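

In this assay, for the compounds shown here, with the trifluoromethyl ring held fixed, the change from 3-methylphenyl to 3-fluorophenyl gives a 7.2-fold lower number from compound 3 to compound 4 (0.86 log units; beyond the scatter), the first direct reading of fluoro in place of methyl at this position. With the 3-fluorophenyl ring held fixed, trifluoromethyl in place of methyl on the other ring gives a 4.6-fold higher number from compound 1 to compound 4 (0.66 log units; beyond the scatter), so the change on that ring can now be read alone. The change from 4-chlorophenyl to 3-fluorophenyl gives an at least 50-fold lower number from compound 2 to compound 4 (1.70 log units; beyond the scatter), but this step is only a bound, as compound 2 stands at a limit: the limit of > 10000 nM in this assay, at which 1 of the 4 values shown sits.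

The compounds shown leave open how a methoxy group, an amine or a nitrile would read on this aromatic carbon. They also leave open whether the step from methyl to fluoro would be the same with methyl rather than trifluoromethyl on the other ring.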